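From an acid to an isopropyl amide on a shared core

The compounds below may be only part of what the source reports. "The series", "measured", "known", "first", "only" and "open" are said of these compounds alone.

Compound 1 `Cc1nc(-c2ccc(C(F)(F)F)cc2)sc1CNc1ccc(CC(=O)O)cc1` is known only through a limit: in a functional assay on CHO cells for agonist activity at Free fatty acid receptor 1 (Homo sapiens) (a higher number here means that more compound is needed for the effect, a lower number that less compound is needed), compound 1 gives < 10000 nM, which is a limit of the assay and not a number. Two further compounds carry the same anilino linkage to a benzyl group. Compound 2 `CC(C)(Oc1ccc(NCc2cccc(Oc3ccccc3)c2)cc1)C(=O)O` also stops at a limit, giving < 10000 nM in this assay. Compound 3 `CC(Cc1ccc(NCc2cccc(Oc3ccccc3)c2)cc1)C(=O)O` gives 100 nM in this assay. The step that the limit leaves unreadable from compound 2 to compound 3 cannot be read because the limit of < 10000 nM in this assay, at which 2 of the 3 values shown sit, covers two of the three values.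

Compound 4 `Cc1nc(-c2ccc(C(F)(F)F)cc2)sc1CNc1ccc(CCC(=O)NC(C)C)cc1` differs from compound 1 by (isopropylcarbamoyl)methyl in place of carboxy on a saturated chain carbon bound to an aromatic carbon. Within the data shown here, no measured step concerns the exchange of the carboxy group for an amide, and the only step between measured compounds remains unreadable, so neither size nor direction can be taken from it. Compound 4 is estimated at 3000 nM, with a range from 300 nM to 20000 nM. Among the measured compounds shown here, this expectation corresponds to the step that the limit leaves unreadable from compound 1 to compound 4, which rests on no measured step and is therefore set wide.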

Compound 4, half-maximal effective concentration: 100 nM
For compound 4 the middle estimate is 30-fold (1.48 log units) above the measured one; measured number outside the range, below it.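

No new step can be read from compound 1 to compound 4, because compound 1 is known only through a limit of the assay: the limit of < 10000 nM in this assay, at which 2 of the 4 values shown sit. The compounds shown leave open how much, and in which direction, (isopropylcarbamoyl)methyl in place of carboxy changes the result on this shared core.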